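Methoxy on the pendant phenyl: compound 2 to compound 4

A few compounds are considered here, and "the series" means these few. Any claim that something is new, unique, unknown or untested is made for them only; others in the source may bear on it.

Compound 1 `C/C(=N\NC(=O)c1cc(-c2ccccc2)nn1Cc1ccc(C(C)(C)C)cc1)c1cc(Cl)ccc1O` gives 2770 nM in a functional assay on A549 cells (Homo sapiens) for inhibition, read by MTT assay, with a stated time of 48 h; a higher number here means a weaker inhibitor, a lower number a stronger inhibitor.
Compound 2 `C/C(=N\NC(=O)c1cc(-c2ccccc2)nn1Cc1ccc(C(C)(C)C)cc1)c1cc(Cl)cc(Cl)c1O` gives 3170 nM in this assay.
Compound 3 `COc1ccc(-c2cc(C(=O)N/N=C(\C)c3cc(C)ccc3O)n(Cc3ccc(C(C)(C)C)cc3)n2)cc1` gives 10400 nM in this assay.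

Compound 2 holds the second highest of the three numbers in this assay. Its nearest neighbour is compound 1: the step of a 1.1-fold higher number from compound 1 to compound 2 (0.06 log units; within the scatter) lies within the scatter, so the two cannot be ordered. Compound 3, the furthest from compound 2, gives a number that lies beyond the scatter in the direction of weaker inhibition; compound 3 differs from compound 2 in two places, not one.

Compound 4 `COc1ccc(-c2cc(C(=O)N/N=C(\C)c3cc(Cl)cc(Cl)c3O)n(Cc3ccc(C(C)(C)C)cc3)n2)cc1` differs from compound 2 by methoxy in place of hydrogen on an aromatic carbon. Within the data shown here, no measured step isolates this change. Among the measured compounds shown here, the only measured step, a 1.1-fold higher number from compound 1 to compound 2 (0.06 log units; within the scatter), concerns the other ring and is within the scatter, so it says nothing about the methoxy. Compound 3 does carry the methoxyphenyl, but also a methyl in place of the two chlorines, so its higher number cannot be credited to the methoxy alone. On this thin basis a modest rise in number is expected for compound 4, a step of a 1.6-fold higher number from compound 2 to compound 4 (0.20 log units; within the scatter) from compound 2, with wide uncertainty. The estimate for compound 4 in this assay is 5000 nM, within a range of 2500 nM to 12000 nM.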

Compound 4, half-maximal inhibitory concentration: 2080 nM
Estimate against measurement, compound 4: 2.4-fold (0.38 log units) above; the measured number lies below the stated range.
By their numbers in this assay, from the lowest: compounds 4, 1 and 2 (each within the scatter of the next); then compound 3.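

Working notes on the pendant phenyl: in this assay, the change from phenyl to 4-methoxyphenyl, on an aromatic carbon para to a large group, can now be read directly, with the 3,5-dichloro-2-hydroxyphenyl group held constant. The step is a 1.5-fold lower number from compound 2 to compound 4 (0.18 log units; within the scatter), so this pair gives no measurable separation, and methoxy is accepted at this position without a loss that can be told from the scatter. With the 4-methoxyphenyl group now held constant, the other ring can be read as well: 3,5-dichloro-2-hydroxyphenyl in place of 2-hydroxy-5-methylphenyl gives a 5.0-fold lower number from compound 3 to compound 4 (0.70 log units; beyond the scatter), so the high number of compound 3 goes with its 2-hydroxy-5-methylphenyl group and not with the methoxy.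

No measured data bear on the reason for either step.

Going by these compounds, the methoxy step is available only with the 3,5-dichloro-2-hydroxyphenyl group, so whether it reads the same with the 2-hydroxy-5-methylphenyl group stays open. Also open, on these data alone, is how far this carbon of the pendant phenyl accepts other groups, such as an amine, a carboxylic acid or a longer alkoxy chain.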